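This account rests on a few compounds, and the source may have more. Where it says the series, first, only, none or still open, it means among the compounds named here.

Measured compounds:
compound 1, `O=S(=O)(Nc1ccc(-c2nc3ccccc3o2)cc1)c1ccc(F)c(C(F)(F)F)c1`, 28000 nM
compound 2, `C=Cc1ccc(S(=O)(=O)Nc2ccc(-c3nc4ccccc4o3)cc2)cc1`, > 100000 nM

In an assay on cells for inhibition of HSP60/HSP10 (Homo sapiens), with a stated time of 60 min (a higher number here means a weaker inhibitor, a lower number a stronger inhibitor), compound 1 gives 28000 nM. Compound 2 is reported in this assay only as a limit, > 100000 nM, and it stands at the limit of > 100000 nM in this assay, at which 1 of the 2 values shown sits. Compound 3, `O=S(=O)(Nc1ccc(-c2nc3ccccc3o2)cc1)c1ccc(F)cc1`, has not yet been measured in this assay; it differs from compound 2 by fluoro in place of vinyl on an aromatic carbon. Among the compounds with values here, no measured step joins these two compounds, so the size of the change cannot be read off and can only be expected. Within the data shown here, with compound 2 at the limit, a change from compound 2 to compound 3 would show in the numbers only if compound 3 turned out a much stronger inhibitor, and nothing among the measured compounds points that way. The estimate for compound 3 in this assay is therefore a weak inhibitor at about 80000 nM, expected to fall between 20000 nM and 300000 nM. The step that this estimate implies is expected to be an at least 1.2-fold lower number from compound 2 to compound 3 (0.09 log units; that floor lies within the scatter).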

Compound 3, half-maximal inhibitory concentration: 73000 nM
For compound 3 the middle estimate is 1.1-fold (0.04 log units) above the measured one, and the stated range covers the measured number.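

In this assay, fluoro in place of vinyl, para to a large group, gives an at least 1.3-fold lower number from compound 2 to compound 3 (0.13 log units; that floor lies within the scatter), so this position now has a measured number for one group. As far as these compounds go, that step is only a floor and its true size stays unknown, since compound 2 is reported only as a limit, > 100000 nM. With the fluoro kept, hydrogen in place of trifluoromethyl gives a 2.6-fold higher number from compound 1 to compound 3 (0.42 log units; beyond the scatter), so the stronger inhibition among the compounds with a number goes with the trifluoromethyl group.

From the compounds shown here alone, whether an amine, a methoxy group or a carboxylic acid in place of the fluoro would move the number in either direction remains open. Going by these compounds, it is also open whether chlorine or a nitrile could stand in for the trifluoromethyl group, and how far any of these steps would carry to a changed core.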